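The source may report more compounds than this note shows. Statements on the series, on what has been measured and on what is new or still open speak of the compounds shown alone.

Measured so far:
compound 1, `Nc1nc(Cl)nc(Nc2ccc(N3CCOCC3=O)cc2)n1`: in a functional assay on the whole organism (strain Swiss) for inhibition, with Mus musculus as the target, with a stated time of 30 min, at a dose of 5 mg/kg by the intraperitoneal route (on this read-out higher numbers stand for a stronger effect at the one dose given and lower numbers for a weaker effect), compound 1 gives 67%
compound 2, `COc1ccc(Nc2nc(Cl)nc(Nc3ccc(N4CCOCC4=O)cc3)n2)cc1`: in this assay compound 2 gives 47%

Among the measured compounds shown here, of the two numbers, compound 2 stands lowest; the single step in the set, a number 20 percentage points lower from compound 1 to compound 2 (beyond the scatter), separates it from compound 1, and that gap lies beyond the scatter.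

Compound 3, `O=C1COCCN1c1ccc(Nc2nc(Cl)nc(Nc3ccc(O)cc3)n2)cc1`, is the next member. Its change from compound 2 is hydrogen in place of methyl on an oxygen on an aromatic ring. For the measured compounds named here, no measured step speaks to this change: the only step in hand concerns a 4-methoxyphenyl placed on a nitrogen on an aromatic ring, not the oxygen on an aromatic ring, so it gives no direction. The removal is a single carbon with no ring and no change in donor or acceptor count. Expectation for this assay is therefore no step beyond the scatter, written as a number 3 percentage points higher from compound 2 to compound 3 (within the scatter). Compound 3 is estimated at 50%, within 30% to 70%.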

Compound 3, a percentage reported as inhibition, in the whole organism at one dose (the size of the read-out at that dose, not a potency): 56%
Compound 3: the middle estimate sits 6 percentage points below what was measured; the range from low to high includes it.
By their numbers in this assay, from the lowest: compounds 2 and 3 (each within the scatter of the next); then compound 1.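

In this assay, the change from 4-methoxyphenyl to 4-hydroxyphenyl gives a number 9 percentage points higher from compound 2 to compound 3 (within the scatter) and so shows that this methyl can leave the oxygen on an aromatic ring without a step that stands clear of the scatter. Compared with hydrogen on the nitrogen, 4-hydroxyphenyl gives a number 11 percentage points lower from compound 1 to compound 3 (beyond the scatter) in this assay and, like 4-methoxyphenyl, stands beyond the scatter, so the drop from compound 1 is not confined to the methoxy form. No available evidence bears on the reason for either step.

On these data alone, it remains open whether a longer chain such as ethyl on that oxygen, or an amine or a carboxylic acid in place of the hydroxy group, would stay within the scatter of compound 3. As far as these compounds go, it is also open whether a plain phenyl on the nitrogen would carry the same drop from compound 1.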